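Compound 3 and the limit of the cytotoxicity read-out

The source may hold more compounds than are shown below. What is called first, only, known or untested is meant among the compounds shown, and "the series" means these compounds.

compound 1 `COc1ccc(/C=C/C(=O)/C=C/c2cc3ccccc3nc2Oc2cccc(Cl)c2)c(OC)c1` gives > 10000 nM as a limit
compound 2 `COc1ccc(OC)c(/C=C/C(=O)/C=C/c2cc3ccccc3nc2Oc2cccc(Cl)c2)c1` gives > 10000 nM as a limit

In a functional assay on 4T1 cells (Mus musculus) for cytotoxicity, read by MTT assay, with a stated time of 48 h (on this read-out lower numbers stand for stronger inhibition and higher numbers for weaker inhibition), compound 2 gives > 10000 nM and this is a limit of the assay, not a number. Both measured compounds share the limit of > 10000 nM in this assay, at which 2 of the 2 values shown sit, and their standing goes no further than that. The compound still to be measured, compound 3 `COc1ccc(/C=C/C(=O)/C=C/c2cc3ccccc3nc2Oc2cccc(Cl)c2)cc1OC`, differs from compound 2 in one place: 3,4-dimethoxyphenyl in place of 2,5-dimethoxyphenyl on a double-bonded chain carbon bound to a double-bonded chain carbon with 3,4-dimethoxyphenyl in place of 2,5-dimethoxyphenyl on a double-bonded chain carbon bound to a double-bonded chain carbon. Within the data shown here, the one measured step at this place is a step that the two limits leave unreadable from compound 1 to compound 2 and it offers no size to carry over. Among the measured compounds shown here, no step of a known size or direction can therefore be expected from it, and another report at the limit seems the likeliest outcome. For compound 3 the estimate in this assay is 12000 nM with an expected range from 4000 nM to 30000 nM on this read-out. The expected change is a step that the limit leaves unreadable from compound 2 to compound 3 as an estimate only.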

Compound 3, half-maximal inhibitory concentration: > 10000 nM
Compound 3: only a limit was reported; the forecaster's own chance of this, stated with the estimate: 70%; the middle value does not contradict the limit.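

Compound 3, like compound 1 and compound 2, reaches only a limit and not a number, so no step among these three compounds can be read in this assay: the limit of > 10000 nM in this assay, at which 3 of the 3 values shown sit.

The compounds shown leave open whether the 2,4-dimethoxyphenyl, 2,5-dimethoxyphenyl and 3,4-dimethoxyphenyl groups differ at all in this assay.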